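This account rests on a few compounds, and the source may have more. Where it says the series, first, only, none or still open, it means among the compounds named here.

Three compounds share one core, an amide that joins a ring carrying carboxylic acid groups to a second ring carrying a single group at the far end. Compound 1, `O=C(Nc1ccc(C(=O)O)c(C(=O)O)c1)c1ccc([N+](=O)[O-])cc1`, gives 13.2 mg/kg in a functional assay on the whole organism with Rattus norvegicus as the target, at a dose of 25 mg/kg by the intravenous route; a higher number here means that more compound is needed for the effect, a lower number that less compound is needed. Compound 2, `O=C(O)c1cc(NC(=O)c2ccc([N+](=O)[O-])cc2)cc(C(=O)O)c1`, gives 9.8 mg/kg in this assay, and compound 3, `N#Cc1ccc(C(=O)Nc2cc(C(N)=O)cc(C(=O)O)c2)cc1`, gives 5.7 mg/kg in this assay. Among these three numbers compound 2 stands second highest; its nearest neighbour is compound 1, whose number lies within the scatter of compound 2, and compound 3, the furthest, also lies within the scatter, so the three readings cannot be told apart.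

Compound 4, `O=C(O)c1cc(NC(=O)c2ccc(-c3nn[nH]n3)cc2)cc(C(=O)O)c1`, has not yet been measured in this assay. It differs from compound 2 in one place: 2H-tetrazol-5-yl in place of nitro on an aromatic carbon. The exchange sits on an aromatic carbon of a six-membered aromatic ring of carbon only, para to a large group. Among the compounds with values here, no measured pair shows this exchange, so the size of the step has no precedent here; the expectation is for a step no larger than the scatter, in either direction. Compound 4 is therefore expected to give 9 mg/kg, within a range from 4 mg/kg to 20 mg/kg, because compound 2 gives 9.8 mg/kg. The expected step is a 1.1-fold lower number from compound 2 to compound 4 (0.04 log units; within the scatter).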

Compound 4, dose for 50% inhibition: 1.2 mg/kg
Beside the measured number, compound 4's estimate is 7.5-fold (0.88 log units) above it; the measured number lies below the stated range.
By their numbers in this assay, from the lowest: compound 4; then compounds 3, 2 and 1 (each within the scatter of the next, the first and the last beyond it).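

The exchange of nitro for 2H-tetrazol-5-yl on an aromatic carbon, para to a large group, gives an 8.2-fold lower number from compound 2 to compound 4 (0.91 log units; beyond the scatter) in this assay. Within the data shown here, this is the first step that can be read, as no earlier pair differed in one place, and it shows that the number in this assay responds to what this position carries. The entering group brings a five-membered aromatic ring and a hydrogen-bond donor, both absent from nitro, but nothing at hand bears on which feature of the change, if any, accounts for the lower number.

The compounds shown leave open whether the step is particular to 2H-tetrazol-5-yl or would also appear with a carboxylic acid or an amine at this position on the core of compound 2. They also leave open whether the same exchange on the core of compound 1 would give a step of similar size.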